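Amino in Place of Methoxy: What One Step Suggests

A few compounds are considered here, and "the series" means these few. Any claim that something is new, unique, unknown or untested is made for them only; others in the source may bear on it.

Measured compounds:
compound 1, `Nc1ccccc1/C=C/c1cccc(O)c1`, 20 ug/mL
compound 2, `COc1ccc(/C=C/c2ccccc2O)cc1`, 21 ug/mL
compound 3, `COc1ccccc1/C=C/c1cccc(O)c1`, 24 ug/mL

All three were tested in an ADME assay on HEK293 cells (Homo sapiens) for inhibition, read by MTT assay, with a stated time of 2 days; on this read-out lower numbers stand for stronger inhibition and higher numbers for weaker inhibition. Their numbers sit close together, and each pair lies within the usual scatter of repeated measurements, so none of the three can be called stronger or weaker than another on this evidence.

Compound 3 and compound 1 differ in one place: amino in place of methoxy on an aromatic carbon. The step that this change made is a 1.2-fold lower number from compound 3 to compound 1 (0.08 log units; within the scatter), a difference too small to count as a real change in this assay.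

Compound 4, `Nc1ccc(/C=C/c2ccccc2O)cc1`, has not yet been measured. It is related to compound 2 by the same kind of change: amino in place of methoxy on an aromatic carbon. The surroundings of the change are not identical, though. In the pair of compound 3 and compound 1 the amino group sits ortho to a group of 9 heavy atoms, while in compound 4 it sits para to a group of 9 heavy atoms. The cores of compound 2 and compound 3 are built from the same atoms joined differently, and the difference between the two cores is not broken down here.

Because the earlier step of a 1.2-fold lower number from compound 3 to compound 1 (0.08 log units; within the scatter) stayed within the scatter, the step expected from compound 2 to compound 4 is also small, about a 1.2-fold lower number from compound 2 to compound 4 (0.07 log units; within the scatter). Compound 4 is therefore estimated at 18 ug/mL in this assay, with a likely range from 9 ug/mL to 36 ug/mL.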

Compound 4, half-maximal inhibitory concentration: 21.4 ug/mL
Compound 4: the middle estimate sits 1.2-fold (0.08 log units) below what was measured; the measured number falls inside the stated range.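

In this assay, putting amino in place of methoxy on the core of compound 2 gives a 1.0-fold higher number from compound 2 to compound 4 (0.01 log units; within the scatter), so here too the change leaves no difference that can be told apart from ordinary scatter. Set side by side, the two steps agree as far as this assay can tell: the same change on two cores in this assay, a 1.2-fold lower number (0.08 log units; within the scatter) from compound 3 to compound 1 and a 1.0-fold higher number (0.01 log units; within the scatter) from compound 2 to compound 4, 1.2-fold (0.09 log units) apart, within the scatter of two such steps. This shows that, on these two closely related cores, the swap behaves alike in the plain sense that neither step rises out of the scatter; it does not show that the change carries a real effect from one core to the other, since two steps this small could hide a weak effect or reflect none at all, and two cores are too few to predict what a third would do.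

The compounds shown hold only amino and methoxy at the changed place, so it stays open whether a different group there, such as a carboxylic acid, a nitrile or a longer chain like butoxy, would move the number beyond the scatter. Going by these compounds, it also stays open whether the amino and methoxy pair would remain this close in a test other than this one cell assay.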